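Cytotoxicity limits across compounds 1 to 4

The source may hold more compounds than are shown below. What is called first, only, known or untested is meant among the compounds shown, and "the series" means these compounds.

Compound 1 `COc1ccc(-c2cc(C(=O)OCc3ccccc3)c3ccccc3n2)cc1` gives > 20000 nM in an ADME assay on HepG2 2.2.15 cells (Homo sapiens) for cytotoxicity, read by MTT assay, with stated times of 3 days and 7 days (a lower number here means that less compound is tolerated, a higher number that more compound is tolerated), a limit of the assay. Compound 2 `Cc1ccc(-c2cc(C(=O)N3CCC(Cc4ccccc4)CC3)c3ccccc3n2)cc1` gives > 20000 nM in this assay, again a limit. Compound 3 `CC(C)Cc1ccc(-c2cc(C(=O)N3CCC(Cc4ccccc4)CC3)c3ccccc3n2)cc1` likewise gives > 20000 nM in this assay, a limit. The step that the two limits leave unreadable from compound 2 to compound 3 is therefore unreadable, and compound 3 stands where (the limit of > 20000 nM in this assay, at which 3 of the 3 values shown sit). Compound 4 `O=C(c1cc(-c2cccc(Br)c2)nc2ccccc12)N1CCC(Cc2ccccc2)CC1` differs from compound 3 by 3-bromophenyl in place of 4-isobutylphenyl on an aromatic carbon. Among the compounds with values here, no measured step bears on this change, and none of the measured values is a number; the only guide is that all three values sit at the limit. For compound 4 the expected step is a step that the limit leaves unreadable from compound 3 to compound 4. Compound 4 is thus estimated at 30000 nM, with a range from 10000 nM to 100000 nM.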

Compound 4, half-maximal cytotoxic concentration: > 20000 nM
Compound 4: only a limit was reported; the forecaster's own chance of this, stated with the estimate: 75%; the middle value is on the limit's open side.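

In this assay, within the data shown here, compound 4 gives > 20000 nM as a further limit, so no step from compound 2 or compound 3 to compound 4 can be read. The compounds shown leave open where the half-maximal cytotoxic concentration of any of them actually lies: the limit of > 20000 nM in this assay, at which 4 of the 4 values shown sit.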